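The compounds below may be only part of what the source reports. "The series", "measured", "known", "first", "only" and "open" are said of these compounds alone.

Within the data shown here, compound 1 `COc1cccc(/C=N/Nc2ncc3c(n2)n(C2CCCC2)c(=O)c(=O)n3C)c1` is one of three compounds measured in a functional assay on PC-3 cells (Homo sapiens) for antiproliferative activity, read by MTT assay (a lower number here means a stronger inhibitor, a higher number a weaker inhibitor), where compound 1 gives 20700 nM, the second highest of the three numbers. Its nearest neighbour is compound 2 `Cn1c(=O)c(=O)n(C2CCCC2)c2nc(N/N=C/c3ccc(C(F)(F)F)cc3)ncc21`, which gives 23600 nM; the step of a 1.1-fold higher number from compound 1 to compound 2 (0.06 log units; within the scatter) comes from a 4-(trifluoromethyl)phenyl in place of the 3-methoxyphenyl on a carbon with a double bond to nitrogen. Compound 3 `Cn1c(=O)c(=O)n(C2CCCC2)c2nc(N/N=C/c3cc(C(F)(F)F)c(O)c(C(F)(F)F)c3)ncc21` gives 17700 nM, and its gap to compound 1 also lies within the scatter. Compound 4 `Cc1ccc(/C=N/Nc2ncc3c(n2)n(C2CCCC2)c(=O)c(=O)n3C)cc1C` differs from compound 1 by 3,4-dimethylphenyl in place of 3-methoxyphenyl on a carbon with a double bond to nitrogen. Among the measured compounds shown here, only the step from compound 1 to compound 2 bears on this kind of change, and it stayed within the scatter, so no step beyond the scatter in this assay is expected for compound 4. Compound 4 is therefore estimated at 21000 nM, with a range from 9000 nM to 50000 nM. The expected step is a 1.0-fold higher number from compound 1 to compound 4 (0.01 log units; within the scatter).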

Compound 4, half-maximal inhibitory concentration: 39000 nM
Estimate against measurement, compound 4: 1.9-fold (0.27 log units) below; low and high end bracket the measured number.
By their numbers in this assay, from the lowest: compounds 3, 1, 2 and 4 (each within the scatter of the next, the first and the last beyond it).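

In this assay the 3,4-dimethylphenyl on a carbon with a double bond to nitrogen gives a 1.9-fold higher number from compound 1 to compound 4 (0.28 log units; within the scatter) and a 1.7-fold higher number from compound 2 to compound 4 (0.22 log units; within the scatter). The change to this group, which has no hydrogen-bond acceptor, therefore gives no step beyond the scatter from the 3-methoxyphenyl, which has one, so a third substituted phenyl at this place stays within the scatter of the first two. No evidence is available to explain these numbers. As far as these compounds go, whether an amine or a carboxylic acid on the phenyl ring, or a longer chain in its place, would give a step beyond the scatter remains open.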